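This account rests on a few compounds, and the source may have more. Where it says the series, first, only, none or still open, it means among the compounds named here.

In a functional assay on the whole organism (stomach) for inhibition, with Rattus norvegicus as the target, at a dose of 100 mg/kg by the intraduodenal route (a higher number here means more inhibition at the dose given (going by the name of the read-out), a lower number less inhibition), compound 2 `N=C(S)CCn1nc(-c2ccccc2)c2ccccc2c1=O` gives 73.3%, the highest of the two measured numbers. Compound 1 `Cc1ccc(=O)n(CC(C)C(=N)S)n1` gives 30.2% in the same assay, a number lower by more than the scatter of repeated measurements. Compound 3 `N=C(S)CCn1ncc2ccccc2c1=O` differs from compound 2 by hydrogen in place of phenyl on an aromatic carbon. Among the measured compounds shown here, no measured pair shows this change, so the expected size of the step rests on compound 2 alone. Compound 3 is expected to lose part of the inhibition of compound 2, a step of a number 28.3 percentage points lower from compound 2 to compound 3 (beyond the scatter) beyond the scatter and downward. Compound 3 is therefore estimated at 45%, within a range from 20% to 70%.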

Compound 3, a percentage reported as inhibition, in the whole organism at one dose (the size of the read-out at that dose, not a potency): 58.3%
For compound 3 the middle estimate is 13.3 percentage points below the measured one; low and high end bracket the measured number.
By their numbers in this assay, from the lowest: compound 1; then compound 3; then compound 2.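

Hydrogen in place of phenyl on this aromatic carbon gives a number 15 percentage points lower from compound 2 to compound 3 (beyond the scatter) in this assay, the first measured change at this position. Phenyl is therefore not required for inhibition at this dose, since compound 3 still gives 58.3% without it. No measurement shown here accounts for the size of this step.

The compounds shown leave open whether methyl, methoxy or an amine on the same carbon would match compound 2 or compound 3. Compound 1 differs from both in more than one place, so it cannot settle this.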